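Adding a Side Chain to an Inactive Compound

This account rests on a few compounds, and the source may have more. Where it says the series, first, only, none or still open, it means among the compounds named here.

- compound 1 (`CC1=CC[C@H]2[C@@H]1CC=C(C)[C@@H](CC[C@H]1[C@]3(C)CC[C@H](O)C(C)(C)O[C@H]3CC[C@@]1(C)O)C2(C)C`) in a functional assay on MDA-MB-231 cells (Homo sapiens) for antiproliferative activity, read by MTT assay, with a stated time of 72 h (on this read-out higher numbers stand for weaker inhibition and lower numbers for stronger inhibition), gives > 50000 nM (a limit of the assay, not a number)
- compound 2 (`CC1=CC[C@H]2[C@H](CC[C@]2(C)O)C(C)(C)[C@@H]1CC[C@H]1[C@]2(C)CC[C@H](OC(=O)c3ccccc3)C(C)(C)O[C@H]2CC[C@@]1(C)O`) in this assay gives 16100 nM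

Compound 1 has no exact value and stands only at a limit (the limit of > 50000 nM in this assay, at which 1 of the 2 values shown sits). Compound 3 (`CC1=CC[C@H]2[C@@H]1CC=C(C)[C@@H](CC[C@H]1[C@]3(C)CC[C@H](OC(=O)CCC(=O)O)C(C)(C)O[C@H]3CC[C@@]1(C)O)C2(C)C`) keeps the core of compound 1 but changes one site, hydroxy to ((2-carboxyethyl)carbonyl)oxy ((2-carboxyethyl)carbonyl in place of hydrogen on an oxygen on a saturated carbon). This places (2-carboxyethyl)carbonyl in place of hydrogen on an oxygen on a saturated carbon. Among the measured compounds shown here, no measured pair isolates this kind of change, so the forecast is uncertain. For the measured compounds named here, the only exact value comes from compound 2 (16100 nM), and it serves as a rough guide to scale. A modest step toward stronger inhibition is expected in this assay, estimated as an at least 2.7-fold lower number from compound 1 to compound 3 (0.44 log units; beyond the scatter) in this case. Compound 3 is expected to give about 18000 nM in this assay, with an estimated range from 6000 nM to 50000 nM and a real chance of another limit.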

Compound 3, half-maximal inhibitory concentration: 29600 nM
Compound 3: middle estimate off by 1.6-fold (0.22 log units), on the low side, within the range that was stated.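

Compound 3 shows that the oxygen on a saturated carbon can carry (2-carboxyethyl)carbonyl in place of hydrogen and still give an exact number in this assay. The change reads as an at least 1.6-fold lower number from compound 1 to compound 3 (0.22 log units; that floor lies within the scatter), and because that floor lies within the scatter, this pair alone does not establish a real gain in inhibition. Compound 1 gives only a limit, so the true size of the step stays unknown: the limit of > 50000 nM in this assay, at which 1 of the 3 values shown sits.

The pair also leaves open how much of the result depends on the acid end of this chain, which a methyl ester at the same place would test. As far as these compounds go, whether a longer chain, or an amine at the end of the chain, would give a lower number on this read-out also remains open.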